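A few compounds are considered here, and "the series" means these few. Any claim that something is new, unique, unknown or untested is made for them only; others in the source may bear on it.

Two compounds of the series have so far been run in a functional assay on NCI-H226 cells (Homo sapiens) for inhibition, read by MTT assay, with a stated time of 48 h, tested at 10 uM; a higher number here means more inhibition at the concentration tested (going by the name of the read-out), a lower number less inhibition. Compound 1 `COc1cc(NC(=O)Nc2cc(Nc3ccc(C(C)(C)C)cc3)ncn2)cc(OC)c1` gives 47.7% in this assay, the highest of the two numbers recorded. Compound 2 `COc1cc(Br)ccc1Nc1cc(NC(=O)Nc2c(Cl)cccc2Cl)ncn1` gives 43% in this assay, and its gap to compound 1 lies within the scatter, so the two cannot be told apart on these data. Compound 3 `COc1cc(NC(=O)Nc2cc(Nc3cc(Br)ccc3OC)ncn2)cc(OC)c1` has not yet been measured. It differs from compound 1 in one place (5-bromo-2-methoxyphenyl in place of 4-(tert-butyl)phenyl on a nitrogen on an aromatic ring). Compound 2 already carries the same 5-bromo-2-methoxyphenyl on the nitrogen on the aromatic ring, with a different group on the urea, and compound 2 comes out at 43%, close to compound 1. For the measured compounds named here, no step between measured compounds is known, so any expectation rests on that comparison: a shift within the scatter, if any, is expected, since compound 2 gives 43%. The step is expected to be a number 4.7 percentage points lower from compound 1 to compound 3 (within the scatter). Compound 3 is estimated at 43%, with a range from 25% to 60%.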

Compound 3, a percentage reported as inhibition, at one concentration (the size of the read-out at that concentration, not a potency): 42.7%
For compound 3 the middle estimate is 0.3 percentage points above the measured one; the range from low to high includes it.
By their numbers in this assay, from the lowest: compounds 3, 2 and 1 (each within the scatter of the next).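

For the compounds shown here, on the nitrogen on an aromatic ring, the exchange of 4-(tert-butyl)phenyl for 5-bromo-2-methoxyphenyl is the only single change with a readable step so far, and in this assay it gives a number 5 percentage points lower from compound 1 to compound 3 (within the scatter). At the concentration tested, this position therefore accepts two differently substituted aryl groups, one with a hydrogen-bond acceptor and one without, and the read-out does not separate them. Nothing available bears on why the two groups read alike.

From the compounds shown here alone, it remains open whether the same holds for a group of another kind on that nitrogen, such as a simple alkyl chain or a ring carrying a carboxylic acid. Going by these compounds, with readings at one concentration only, it also remains open whether compound 1 and compound 3 would match across a range of concentrations.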